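The source may report more compounds than this note shows. Statements on the series, on what has been measured and on what is new or still open speak of the compounds shown alone.

Three compounds share one core and differ only in the halogen on the benzyl ring. In an ADME assay on CHO-K1 cells (Cricetulus griseus) for cytotoxicity, read by MTT assay, with a stated time of 24 h (a lower number here means a stronger inhibitor, a higher number a weaker inhibitor), compound 1 `O=[N+]([O-])c1cc(-c2nnn(Cc3cccc(Cl)c3)n2)cc([N+](=O)[O-])c1` gives 27000 nM. Compound 2 `O=[N+]([O-])c1cc(-c2nnn(Cc3cccc(Br)c3)n2)cc([N+](=O)[O-])c1` gives 29000 nM in this assay, and the change from chloro to bromo brings a 1.1-fold higher number from compound 1 to compound 2 (0.03 log units; within the scatter). Compound 3 `O=[N+]([O-])c1cc(-c2nnn(Cc3cccc(F)c3)n2)cc([N+](=O)[O-])c1` gives 315000 nM in this assay, the highest of the three numbers: a 12-fold higher number from compound 1 to compound 3 (1.07 log units; beyond the scatter) and an 11-fold higher number from compound 2 to compound 3 (1.04 log units; beyond the scatter).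

Compound 4 `COc1cccc(Cn2nnc(-c3cc([N+](=O)[O-])cc([N+](=O)[O-])c3)n2)c1` has not yet been measured. It differs from compound 3 by methoxy in place of fluoro on an aromatic carbon. Among the compounds with values here, no measured step swaps a halogen for methoxy, so nothing speaks directly to this change. What the measured steps do show is that the two large steps both end at the fluoro compound, while chloro and bromo sit together. The change to compound 4 removes the fluoro, so the number is expected to move back toward the values of compound 1 and compound 2, though with wide uncertainty; the expected step is a 3.9-fold lower number from compound 3 to compound 4 (0.60 log units; beyond the scatter). Compound 4 is therefore expected to give about 80000 nM in this assay, within a range from 20000 nM to 320000 nM.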

Compound 4, half-maximal inhibitory concentration: > 100000 nM
Compound 4 was reported as a limit; the forecaster's own chance of this, stated with the estimate: 10%; at least 1.2-fold (0.09 log units) between middle value and limit.
By their numbers in this assay, from the lowest: compounds 1 and 2 (each within the scatter of the next); then compound 3.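

The result for compound 4 in this assay is a limit of the assay and not a number: the limit of > 100000 nM in this assay, at which 1 of the 4 values shown sits. Even so, two steps can be read, an at least 3.4-fold higher number from compound 2 to compound 4 (0.53 log units; beyond the scatter) and an at least 3.7-fold higher number from compound 1 to compound 4 (0.56 log units; beyond the scatter), so methoxy, which carries no halogen, does not join chloro and bromo at the low end of this series. Until now, only fluoro had stood apart from that pair at this aromatic carbon, and compound 4 shows that a second replacement, one with an oxygen and a carbon, also stands apart.

On these data alone, the step from compound 3 to compound 4 cannot be read, so the order of fluoro and methoxy stays open. The compounds shown also leave open where an amine, a carboxylic acid or a longer chain such as ethoxy would fall at this position.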